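A few compounds are considered here, and "the series" means these few. Any claim that something is new, unique, unknown or untested is made for them only; others in the source may bear on it.

Measured compounds in a functional assay on KYSE-410 cells (Homo sapiens) for antiproliferative activity, read by MTT assay, with a stated time of 72 h; on this read-out lower numbers stand for stronger inhibition and higher numbers for weaker inhibition:

Compound 1, `O=C(Nc1ccc(Cl)cc1)c1cc(=O)[nH]c2cc(Br)ccc12`: > 20000 nM, a limit of the assay.
Compound 2, `O=C(Nc1cc(F)ccc1F)c1cc(=O)[nH]c2cc(Br)ccc12`: > 20000 nM, also a limit of the assay.
Compound 3, `O=C(Nc1cccc(F)c1)c1cc(=O)[nH]c2cc(Br)ccc12`: 7300 nM.

Among the compounds with values here, compound 3 is the only member of the set that gives a number in this assay, and its standing follows from the limit of > 20000 nM in this assay, at which 2 of the 3 values shown sit. Both measured steps lead into it: an at least 2.7-fold lower number from compound 1 to compound 3 (0.43 log units; beyond the scatter), and an at least 2.7-fold lower number from compound 2 to compound 3 (0.43 log units; beyond the scatter). Each is at least modest, and each concerns the group on the amide-type nitrogen, while the bromo on the shared core is held fixed in every measured compound.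

Compound 4, `Cc1ccc(-c2ccc3c(C(=O)Nc4cccc(F)c4)cc(=O)[nH]c3c2)cc1`, keeps the 3-fluorophenyl of compound 3 and changes the core instead: 4-methylphenyl in place of bromo on an aromatic carbon. Neither measured step touches this position, so nothing in the data sets the direction or size of the step. Within the data shown here, the change is a large one in what is counted, yet with no measured precedent the expectation stays close to compound 3 and is only loosely bounded. Compound 4 is therefore estimated at 5000 nM, in a range from 800 nM to 20000 nM, so that the expected step is a 1.5-fold lower number from compound 3 to compound 4 (0.16 log units; within the scatter), with a real chance that this assay again reports only a limit.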

Compound 4, half-maximal inhibitory concentration: > 20000 nM
Compound 4 was reported as a limit (the forecaster's own chance of this, stated with the estimate: 25%); middle value at least 4.0-fold (0.60 log units) from the limit.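

In this assay, the position on the core that had stayed fixed as bromo now has its first reading: 4-methylphenyl in place of bromo gives an at least 2.7-fold higher number from compound 3 to compound 4 (0.43 log units; beyond the scatter). Within the data shown here, the direction is therefore set, toward weaker inhibition, and the 3-fluorophenyl on the amide-type nitrogen, which gave the only number among the earlier compounds, does not keep a numerical value through this change, so the group on the core matters as well as the group on that nitrogen. The value of compound 4 is a limit of the assay and not a number, so the step has a lower bound but no known full size, and compound 4 joins the two other compounds at that limit: the limit of > 20000 nM in this assay, at which 3 of the 4 values shown sit.

Open, going by these compounds, is whether any group other than bromo can keep a number at this position, as only bromo and 4-methylphenyl appear there, and a chloro, a methyl, an amine or a phenyl ring carrying a carboxylic acid could each go either way. Also open, on these data alone, is whether the loss belongs to the added ring or to its methyl, which a plain phenyl at the same position would separate.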